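The source may hold more compounds than are shown below. What is called first, only, known or untested is meant among the compounds shown, and "the series" means these compounds.

Compounds measured in a functional assay on MKN-74 cells (Homo sapiens) for antiproliferative activity, with a stated time of 24 h; on this read-out higher numbers stand for weaker inhibition and lower numbers for stronger inhibition:
compound 1 `NC(=O)c1c(NC(=O)c2cccc([N+](=O)[O-])c2)sc2c1CCN(Cc1c(Cl)cccc1Cl)C2` gives 13500 nM
compound 2 `NC(=O)c1c(NC(=O)c2cccc([N+](=O)[O-])c2)sc2c1CCN(Cc1ccc(Cl)cc1Cl)C2` gives 16500 nM
compound 3 `NC(=O)c1c(NC(=O)c2ccc(C(F)(F)F)cc2)sc2c1CCN(C(=S)Nc1ccccc1Cl)C2` gives 16400 nM

Compound 3 stands second highest of the three numbers; its nearest neighbour is compound 2, and both its gaps, to compound 2 and to compound 1, lie within the scatter. Among the measured compounds shown here, the only measured step, a 1.2-fold higher number from compound 1 to compound 2 (0.09 log units; within the scatter), concerns the group on the ring amine and is also within the scatter. For the measured compounds named here, nothing measured so far touches the group on the carbonyl carbon directly.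

Compound 4 `NC(=O)c1c(NC(=O)c2cccc([N+](=O)[O-])c2)sc2c1CCN(C(=S)Nc1ccccc1Cl)C2` differs from compound 3 in one place: 3-nitrophenyl in place of 4-(trifluoromethyl)phenyl on a carbonyl carbon. Compounds 1 and 2 carry the same 3-nitrophenyl on that carbonyl carbon and sit at the same level as compound 3, so no bearing on the size of this change can be drawn beyond that the three numbers agree. The expectation for this assay is therefore a step of a 1.1-fold lower number from compound 3 to compound 4 (0.04 log units; within the scatter), that is none beyond the scatter. Compound 4 is estimated at 15000 nM, with a range from 6000 nM to 40000 nM.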

Compound 4, half-maximal inhibitory concentration: 8850 nM
Beside the measured number, compound 4's estimate is 1.7-fold (0.23 log units) above it, and the stated range covers the measured number.
By their numbers in this assay, from the lowest: compounds 4, 1, 3 and 2 (each within the scatter of the next).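

Working notes: in this assay the first direct comparison on the carbonyl carbon, a 1.9-fold lower number from compound 3 to compound 4 (0.27 log units; within the scatter), stays within the scatter, so this exchange of 4-(trifluoromethyl)phenyl for 3-nitrophenyl shows no measurable effect with this group on the ring amine. On the amine nitrogen in a ring, a 1.9-fold lower number from compound 2 to compound 4 (0.27 log units; within the scatter) and a 1.5-fold lower number from compound 1 to compound 4 (0.18 log units; within the scatter) also stay within the scatter, which extends the flat picture to the sulfur-containing group of compound 4 and the dichlorophenyl-bearing groups of compound 1 and compound 2. No measured evidence bears on the result.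

Still open is whether any change at either place moves the number beyond the scatter, since every step shown stays within it. A carboxylic acid or an amine on the aromatic ring of the carbonyl substituent, or a longer chain in place of that ring, would test this.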